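The source may report more compounds than this note shows. Statements on the series, on what has been measured and on what is new or still open speak of the compounds shown alone.

Measured in an assay on isolated protein for inhibition of Calpain-1 catalytic subunit (Sus scrofa), read by FRET; on this read-out higher numbers stand for weaker inhibition and lower numbers for stronger inhibition:

compound 1 `O=C(O)/C(S)=C/c1c[nH]c2cc(Cl)ccc12` gives 210 nM
compound 2 `O=C(O)/C(S)=C/c1c[nH]c2ccc(I)cc12` gives 100 nM
compound 3 `O=C(O)/C(S)=C/c1c[nH]c2cccc(F)c12` gives 10 nM

Compound 3 holds the lowest number of the three in this assay; its gap to compound 2 and its wider gap to compound 1 both lie beyond the scatter, so it is the strongest inhibitor among the measured set. Going by the values given here, compound 1 and compound 2 each differ from compound 3 in both the halogen and the place it occupies on the shared core, so no measured pair isolates a single change, and no step between measured compounds can be read off.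

Compound 4 `O=C(O)/C(S)=C/c1c[nH]c2cccc(Br)c12` differs from compound 3 by bromo in place of fluoro on an aromatic carbon. Among the compounds with values here, no measured pair shows a halogen exchange at a fixed place on the shared core, so direction cannot be taken from the three numbers. The expectation for compound 4 is a small step, written as a 2.0-fold higher number from compound 3 to compound 4 (0.30 log units; within the scatter), kept close to the scatter. Compound 4 is therefore expected to give 20 nM in this assay, with a range from 5 nM to 80 nM.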

Compound 4, half-maximal inhibitory concentration: 6 nM
The estimate for compound 4 lay 3.3-fold (0.52 log units) above the measured number; measured number inside the range.
By their numbers in this assay, from the lowest: compounds 4 and 3 (each within the scatter of the next); then compound 2; then compound 1.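

In this assay, bromo in place of fluoro on this aromatic carbon gives a 1.7-fold lower number from compound 3 to compound 4 (0.22 log units; within the scatter), and this is the only halogen exchange at a fixed place on the shared core among the compounds shown. At this place, then, the two halogens cannot be told apart on this read-out, and compounds 3 and 4 give one level of inhibition within the scatter. Nothing measured here bears on a reason for this result.

Still open, going by these compounds, is whether chloro or iodo on this same carbon, or an amine or a methoxy group there, would hold that level. Compound 1 and compound 2 each differ from compound 3 and compound 4 in both the halogen and its place, so the contribution of place alone remains unresolved.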